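A few compounds are considered here, and "the series" means these few. Any claim that something is new, unique, unknown or untested is made for them only; others in the source may bear on it.

Measured so far:
- compound 1, `CSC1NC(=O)n2cnc(CCCCCOCc3ccccc3)c2N1`, which in a functional assay on CCRF-CEM cells (Homo sapiens) for cytotoxicity (a higher number here means that more compound is tolerated, a lower number that less compound is tolerated), reaches only a limit of the assay, > 120000 nM.
- compound 2, `Cc1ccc(CSC2NC(=O)n3cnc(CCCCCOCc4ccccc4)c3N2)cc1`, which in this assay gives 343000 nM.
- compound 3, `CSc1ncnc2c(Cc3ccc(C)cc3)ncn12`, which in this assay gives 389000 nM.

The step from compound 1 to compound 2 is a step that the limit leaves unreadable from compound 1 to compound 2; the change is 4-methylphenyl in place of hydrogen on a saturated chain carbon bound to a sulfur. Its size cannot be read because compound 1 sits at the limit of > 120000 nM in this assay, at which 1 of the 3 values shown sits. Compound 2 and compound 3 lie within the scatter of each other. How the core of compound 3 differs from the core of compound 1 is not broken down here.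

Compound 4, `Cc1ccc(CSc2ncnc3c(Cc4ccc(C)cc4)ncn23)cc1`, has not yet been measured in this assay. It arises from compound 3 by the same change that leads from compound 1 to compound 2: 4-methylphenyl in place of hydrogen on a saturated chain carbon bound to a sulfur. The measured step from compound 1 to compound 2 is unreadable. The expectation rests on compound 2, which carries the same group and gives 343000 nM in this assay. The step from compound 3 to compound 4 is therefore expected to be small, about a 1.1-fold lower number from compound 3 to compound 4 (0.05 log units; within the scatter). For compound 4 the estimate in this assay is 350000 nM, with a likely range from 150000 nM to 800000 nM.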

Compound 4, half-maximal cytotoxic concentration: > 111000 nM
Compound 4 gave a limit, no number; the forecaster's own chance of this, stated with the estimate: 25%; the middle value does not contradict the limit.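

In this assay compound 4 reaches only a limit of the assay, > 111000 nM. The size of the change from compound 3 to compound 4 therefore cannot be read: the limit of > 111000 nM in this assay, at which 1 of the 4 values shown sits.

The compounds shown leave open whether 4-methylphenyl in place of hydrogen on a saturated chain carbon bound to a sulfur shifts the tolerated concentration at all, on either core.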